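This account rests on a few compounds, and the source may have more. Where it says the series, first, only, none or still open, it means among the compounds named here.

In a functional assay on PC-3 cells (Homo sapiens) for inhibition, read by MTT assay, with a stated time of 48 h (a lower number here means a stronger inhibitor, a higher number a weaker inhibitor), compound 1 `CCSc1nnc(-c2cc(OC)c(OC)c(OC)c2)n1-c1ccc(OC)cc1` gives 57700 nM. Compound 2 `COc1cc(-c2nnc(SC)n2-c2ccc(N(C)C)cc2)cc(OC)c1OC` gives only > 60000 nM, which is a limit of the assay and not a number. Compound 3 `CCSc1nnc(-c2cc(OC)c(OC)c(OC)c2)n1-c1ccc(N(C)C)cc1` differs from compound 2 by methyl in place of hydrogen on a saturated chain carbon bound to a sulfur, turning methylsulfanyl to ethylsulfanyl. Compound 1 also carries ethylsulfanyl and stands at 57700 nM, so only a small change is expected in this assay, in neither direction beyond the scatter. The estimated change is an at least 1.0-fold lower number from compound 2 to compound 3 (0.03 log units; that floor lies within the scatter). For compound 3, the expected value is 55000 nM, with an estimated range of 25000 nM to 100000 nM.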

Compound 3, half-maximal inhibitory concentration: 46200 nM
Estimate against measurement, compound 3: 1.2-fold (0.08 log units) above, and the stated range covers the measured number.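

In this assay, dimethylamino in place of methoxy on an aromatic carbon, with ethylsulfanyl held constant, gives a 1.2-fold lower number from compound 1 to compound 3 (0.10 log units; within the scatter), so at this position the two groups cannot be told apart. Methyl in place of hydrogen on a saturated chain carbon bound to a sulfur gives an at least 1.2-fold lower number from compound 2 to compound 3 (0.11 log units; that floor lies within the scatter), a floor that does not fix the size of the step. Compound 2 stands at a limit of the assay and not a number: the limit of > 60000 nM in this assay, at which 1 of the 3 values shown sits.

Going by these compounds, what stays open is whether a longer chain such as propylsulfanyl, or a carboxylic acid in place of dimethylamino, moves the number beyond the scatter.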